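Replacing a bis(hydroxymethyl)pyrrolidine with isopropylamino

The source may hold more compounds than are shown below. What is called first, only, known or untested is meant among the compounds shown, and "the series" means these compounds.

- Compound 1 `O=C(Nc1ccc(CO)cc1)Nc1ccc(-c2nc(N3C4CCC3COC4)nc(N3C4CCC3COC4)n2)cc1`: > 0.5 h (a limit)
- Compound 2 `CN1CCN(c2ccc(NC(=O)Nc3ccc(-c4nc(N5C6CCC5COC6)nc(N5[C@H](CO)CC[C@@H]5CO)n4)cc3)cc2)CC1`: > 0.5 h (a limit)

In an in vitro ADME assay on microsomes (Mus musculus) for metabolic stability, read by LC-MS, with a stated time of 15 min (on this read-out lower numbers stand for a shorter-lived compound and higher numbers for a longer-lived compound), compound 2 gives > 0.5 h. This value is a limit and not a number. Compound 2 therefore has no exact place on the scale, and the two measured compounds share one position: the limit of > 0.5 h in this assay, at which 2 of the 2 values shown sit.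

Compound 3 `CC(C)Nc1nc(-c2ccc(NC(=O)Nc3ccc(N4CCN(C)CC4)cc3)cc2)nc(N2C3CCC2COC3)n1` has not yet been measured. Its difference from compound 2 is isopropylamino in place of 2,5-bis(hydroxymethyl)pyrrolidin-1-yl on an aromatic carbon. In words, isopropylamino stands in place of 2,5-bis(hydroxymethyl)pyrrolidin-1-yl on an aromatic carbon, between two ring nitrogen atoms.

Among the compounds with values here, no measured pair of compounds shows what a change of this kind does in this assay. The expectation therefore rests on compound 2 alone, at > 0.5 h. No step beyond the usual scatter is expected, in either direction, and a further limit would be no surprise. The expected change is a number no higher from compound 2 to compound 3 (the limit leaves the size open). The half-life expected for compound 3 is 0.5 h, with an estimated range of 0.2 h to 1 h.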

Compound 3, half-life: > 0.5 h
Compound 3 ended at the assay's limit (the forecaster's own chance of this, stated with the estimate: 60%); the middle value lies on the limit itself.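

No step can be read from compound 2 to compound 3, as both values are limits and not numbers: the limit of > 0.5 h in this assay, at which 3 of the 3 values shown sit.

The compounds shown leave open how long each of them lasts beyond that limit, and so whether isopropylamino in place of 2,5-bis(hydroxymethyl)pyrrolidin-1-yl changes the half-life in this assay at all.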